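Trimethoxyphenyl for methylphenyl on the enone chain

The source may hold more compounds than are shown below. What is called first, only, known or untested is meant among the compounds shown, and "the series" means these compounds.

Compound 1 `COc1cc(C(=O)/C=C/c2cc(-c3cc(OC)c(OC)c(OC)c3)n3nc(-c4ccccc4)cc3n2)cc(OC)c1OC`, compound 2 `COc1ccc(-c2cc(C(=O)/C=C/c3ccc(C)cc3)nc3cc(-c4ccccc4)nn23)cc1OC` and compound 3 `COc1cc(-c2cc(/C=C/C(=O)c3ccc(C)cc3)nc3cc(-c4ccccc4)nn23)cc(OC)c1OC` have been run in an ADME assay on HEK293 cells (Homo sapiens) for antiproliferative activity, read by MTT assay, with a stated time of 24 h; a lower number here means a stronger inhibitor, a higher number a weaker inhibitor; compound 4 `COc1ccc(-c2cc(C(=O)/C=C/c3cc(OC)c(OC)c(OC)c3)nc3cc(-c4ccccc4)nn23)cc1OC` has not. In this assay compound 2 gives 57400 nM and compound 3 gives 50400 nM, two numbers within the usual scatter of each other. Compound 1 reaches only a limit of the assay, >= 100000 nM, as recorded in the limit of >= 100000 nM in this assay, at which 1 of the 3 values shown sits. The step of an at least 1.9-fold higher number from compound 3 to compound 1 (0.29 log units; that floor lies within the scatter) follows the change (3,4,5-trimethoxyphenyl in place of 4-methylphenyl on a carbonyl carbon). The change from compound 2 to compound 4 is 3,4,5-trimethoxyphenyl in place of 4-methylphenyl on a double-bonded chain carbon bound to a double-bonded chain carbon, the same kind of change but at a different place: on a double-bonded chain carbon bound to a double-bonded chain carbon rather than on a carbonyl carbon. How the core of compound 2 differs from that of compound 3 is not broken down here. For compound 4 a step of about a 1.7-fold higher number from compound 2 to compound 4 (0.22 log units; within the scatter) is expected, resting on an at least 1.9-fold higher number from compound 3 to compound 1 (0.29 log units; that floor lies within the scatter) and on the value of compound 2, 57400 nM. Compound 4 is therefore estimated at 95000 nM, with a range from 45000 nM to 200000 nM.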

Compound 4, half-maximal inhibitory concentration: 46800 nM
The estimate for compound 4 lay 2.0-fold (0.31 log units) above the measured number; the measured number falls inside the stated range.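

In this assay, 3,4,5-trimethoxyphenyl in place of 4-methylphenyl on a double-bonded chain carbon bound to a double-bonded chain carbon gives a 1.2-fold lower number from compound 2 to compound 4 (0.09 log units; within the scatter), so on this core the change stays within the scatter. Set beside the change on the carbonyl carbon, the comparison reads: the same change on two cores in this assay, an at least 1.9-fold higher number (0.29 log units; that floor lies within the scatter) from compound 3 to compound 1 and a 1.2-fold lower number (0.09 log units; within the scatter) from compound 2 to compound 4; the limit leaves it open whether they differ. Compound 1 gives only a limit of the assay, >= 100000 nM, not a number, and the two steps show neither that the change carries from one core to the other nor that it fails to.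

The compounds shown leave open whether a group other than a substituted phenyl, such as an amine or a carboxylic acid in place of the 4-methylphenyl, would give a step beyond the scatter.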